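Tetrahydroisoquinoline for pyrrolidine on the aminopyrimidine core

The compounds below may be only part of what the source reports. "The series", "measured", "known", "first", "only" and "open" are said of these compounds alone.

Measured so far:
compound 1 `CNC(=O)c1cc(Oc2ccc(Nc3nccc(N4CCCC4)n3)cc2)ccn1`: 3720 nM
compound 2 `CN(c1ccc(Oc2ncnc3ccsc23)cc1)c1nccc(N2CCCC2)n1`: "not determined" (no result reported)
compound 3 `COc1ccc(C[C@H]2C(=O)N[C@@H](C)C(=O)N(C)[C@H]3Cc4cccc(c4)Oc4cc(ccc4O)C[C@H](C(=O)N[C@H](C)C(=O)N[C@@H](C)C(=O)N2C)N(C)C3=O)cc1`: 65 nM

In an assay on HEK293T cells for inhibition of nuclear factor NF-kappa-B complex (Homo sapiens), read by a luciferase reporter, with stated times of 6 h and 8 h (on this read-out higher numbers stand for weaker inhibition and lower numbers for stronger inhibition), compound 1 gives 3720 nM, the highest of the two numbers recorded. The nearest measured entry, compound 3, gives 65 nM, a much lower number, beyond the scatter. Compound 2 carries a related core but has no number, so it adds nothing to the comparison.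

Compound 4 `CNC(=O)c1cc(Oc2ccc(Nc3nccc(N4CCc5ccccc5C4)n3)cc2)ccn1` follows from compound 1 by one change, (1,2,3,4-tetrahydroisoquinolin-2-yl in place of pyrrolidin-1-yl on an aromatic carbon), a larger ring system entering where the small ring left. For the measured compounds named here, no measured pair shows this exchange, so the direction is open. The estimate for compound 4 is 2500 nM, within 700 nM to 9000 nM, a step of a 1.5-fold lower number from compound 1 to compound 4 (0.17 log units; within the scatter) expected to lie near the scatter rather than clearly beyond it.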

Compound 4, half-maximal inhibitory concentration: 7780 nM
For compound 4 the middle estimate is 3.1-fold (0.49 log units) below the measured one, within the range that was stated.
By their numbers in this assay, from the lowest: compound 3; then compound 1; then compound 4.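

In this assay, for the compounds shown here, 1,2,3,4-tetrahydroisoquinolin-2-yl in place of pyrrolidin-1-yl gives a 2.1-fold higher number from compound 1 to compound 4 (0.32 log units; beyond the scatter), the only single-place reading at this aromatic carbon next to the ring nitrogen. The step is modest, so this position accepts the larger group with only a small loss of inhibition. No measurement bears on the reason for this rise.

Open, as far as these compounds go, is whether piperidine, with the six-membered ring but no aromatic ring, would separate the two parts of the exchange. Also open, from the compounds shown here alone, is how a morpholine ring or an open-chain dimethylamino group would read here.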